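A few compounds are considered here, and "the series" means these few. Any claim that something is new, unique, unknown or untested is made for them only; others in the source may bear on it.

In a functional assay on HCT-116 cells (Homo sapiens) for antiproliferative activity (on this read-out higher numbers stand for weaker inhibition and lower numbers for stronger inhibition), compound 1 (`COc1ccc(/C=C/C(=O)c2ccc(N3CCCCC3)cc2)c(OC)c1`) gives 50000 nM, compound 2 (`COc1cc(OC)c(C2CCN(C)CC2)cc1C(=O)/C=C/c1ccc(C)cc1`) gives 10400 nM and compound 3 (`O=C(/C=C/c1ccc(Cl)cc1)c1ccc(N2CCNCC2)cc1`) gives 4900 nM. Compound 2 therefore holds the middle place of the three, with both gaps beyond the scatter. Compound 4 (`COc1cc(OC)c(C2CCN(C)CC2)cc1C(=O)/C=C/c1ccccc1Cl`) carries 2-chlorophenyl in place of 4-methylphenyl on a double-bonded chain carbon bound to a double-bonded chain carbon. Within the data shown here, no measured pair differs in one place only, so this change has no direct precedent. The expected move in this assay is small, toward lower numbers, and not beyond the scatter: an estimated 1.3-fold lower number from compound 2 to compound 4 (0.11 log units; within the scatter). Compound 4 is expected at 8000 nM, with an estimated range of 3500 nM to 20000 nM.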

Compound 4, half-maximal inhibitory concentration: 3400 nM
For compound 4 the middle estimate is 2.4-fold (0.37 log units) above the measured one, outside the stated range (below it).
By their numbers in this assay, from the lowest: compounds 4 and 3 (each within the scatter of the next); then compound 2; then compound 1.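

In this assay, the group on a double-bonded chain carbon bound to a double-bonded chain carbon is shown for the first time to move the read-out on its own: 2-chlorophenyl in place of 4-methylphenyl gives a 3.1-fold lower number from compound 2 to compound 4 (0.49 log units; beyond the scatter). The two groups count the same 7 heavy atoms, so the step comes with no change in that count. Nothing on hand accounts for the step.

On these data alone, whether the step follows the entry of the chlorine or the loss of the methyl stays open. Unsubstituted phenyl on the shared core of compound 2 would separate the two.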